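One Fluorine Atom, Two Cores, One Expected Number

The source may hold more compounds than are shown below. What is called first, only, known or untested is meant among the compounds shown, and "the series" means these compounds.

Of the compounds shown here, three have been measured in an assay on U2OS cells for activation of nuclear factor erythroid 2-related factor 2 (Homo sapiens), read by beta-arrestin recruitment, with a stated time of 6 h; a higher number here means that more compound is needed for the effect, a lower number that less compound is needed. Compound 1, with the structure `O=S(=O)(/C=C/c1ccccn1)c1ccc(F)cc1`, gives 3100 nM. Compound 2, `O=S(=O)(/C=C/c1ncccc1F)c1ccc(F)cc1`, differs from compound 1 by a single atom: fluoro in place of hydrogen on an aromatic carbon. In this assay compound 2 gives 542 nM, so the step is a 5.7-fold lower number from compound 1 to compound 2 (0.76 log units; beyond the scatter).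

Compound 3, `O=S(=O)(/C=C/c1ccccn1)c1ccccc1Cl`, carries a different core; the difference between the core of compound 1 and the core of compound 3 is not broken down here. In this assay compound 3 gives 618 nM, which places it close to compound 2 and well apart from compound 1.

Compound 4, `O=S(=O)(/C=C/c1ncccc1F)c1ccccc1Cl`, has not yet been measured. It stands to compound 3 exactly as compound 2 stands to compound 1: fluoro in place of hydrogen on an aromatic carbon. The place of the change is described in identical words in both pairs, so this is the same change on a second core, and it occurs twice among the four compounds.

For the measured compounds named here, whether the step from compound 1 to compound 2 carries over to the core of compound 3 cannot be checked from the data at hand; only one example of the change has been measured. With that caution, compound 4 is expected to show a step of about a 4.1-fold lower number from compound 3 to compound 4 (0.61 log units; beyond the scatter), somewhat smaller than the earlier step, because the earlier step was a 5.7-fold lower number from compound 1 to compound 2 (0.76 log units; beyond the scatter) and a single measured example is a thin basis. The estimate for compound 4 in this assay is therefore 150 nM, expected to fall between 50 nM and 450 nM.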

Compound 4, half-maximal effective concentration: 122 nM
For compound 4 the middle estimate is 1.2-fold (0.09 log units) above the measured one, within the range that was stated.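

In this assay, fluoro in place of hydrogen on an aromatic carbon of the six-membered aromatic ring with 1 nitrogen gives a 5.1-fold lower number from compound 3 to compound 4 (0.70 log units; beyond the scatter), so the step seen on the core of compound 1 also appears on the core of compound 3. For the compounds shown here, the two steps point the same way and do not differ in size beyond what repeated measurements would be expected to show, which means that, across these two cores, the change can be treated as one step of about the same size: the same change on two cores in this assay, a 5.7-fold lower number (0.76 log units; beyond the scatter) from compound 1 to compound 2 and a 5.1-fold lower number (0.70 log units; beyond the scatter) from compound 3 to compound 4, 1.1-fold (0.05 log units) apart, within the scatter of two such steps This does not show why the number falls, and with only two pairs behind it, the agreement cannot be extended to any other core or to any other read-out.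

The compounds shown leave open whether a methyl group, a methoxy group or a nitrile on that same aromatic carbon would give a step of similar size, and whether fluoro would do so on another carbon of that ring. They also leave open whether the step would hold on a core carrying an amine or a carboxylic acid.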